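The source may hold more compounds than are shown below. What is called first, only, known or untested is meant among the compounds shown, and "the series" means these compounds.

Notes on the series. Of the compounds shown here, three have been measured in an assay on microsomes for inhibition of acyl-CoA desaturase 1 (Mus musculus), with a stated time of 60 min; on this read-out lower numbers stand for stronger inhibition and higher numbers for weaker inhibition. Compound 1 `COc1ccc(/C=C/C(=O)Nc2ncc(Cc3cccc(C(F)(F)F)c3)s2)cc1` gives 2 nM. Compound 2 `COc1cc(C(=O)Nc2ncc(Cc3cccc(C(F)(F)F)c3)s2)ccc1OCCO` gives 3 nM. Compound 3 `COc1ccc(C(=O)Nc2ncc(Cc3cccc(F)c3)s2)cc1OCCO` gives 2 nM. On these numbers compound 3 stands level with compound 1, the two sharing the lowest figure of the three; the figure of compound 2 lies within the scatter of both, so no order among the three can be read from the data. Going by the values given here, none of the three differs from another in one place only, and no single step has therefore been quantified.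

Compound 4 `COc1ccc(C(=O)Nc2ncc(Cc3cc(Cl)cc(Cl)c3)s2)cc1OCCO` is the next to be measured. It differs from compound 3 in one place: 3,5-dichlorophenyl in place of 3-fluorophenyl on a saturated chain carbon bound to an aromatic carbon. Among the compounds with values here, no measured pair shows the effect of this change, since compounds 1 and 2 do not carry the 3-fluorophenyl group and differ from compound 3 elsewhere as well. The expectation for compound 4 therefore rests on compound 3 alone. The step from compound 3 to compound 4 in this assay is expected to be small, a 1.5-fold higher number from compound 3 to compound 4 (0.18 log units; within the scatter), with no direction favoured beyond the scatter. Compound 4 is estimated at 3 nM, within a range from 1 nM to 10 nM.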

Compound 4, half-maximal inhibitory concentration: 0.7 nM
Beside the measured number, compound 4's estimate is 4.3-fold (0.63 log units) above it; the measured number lies below the stated range.
By their numbers in this assay, from the lowest: compound 4; then compounds 1, 3 and 2 (each within the scatter of the next).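

In this assay, 3,5-dichlorophenyl in place of 3-fluorophenyl on a saturated chain carbon bound to an aromatic carbon gives a 2.9-fold lower number from compound 3 to compound 4 (0.46 log units; beyond the scatter). Going by these compounds alone, this is the first single-place step quantified, and it shows that the figure still responds to a change at this position, which the three earlier values, all within the scatter of one another, could not show. The change swaps the halogen and alters the number of halogens at once, so this one pair cannot separate the two, and no measurement is available that accounts for the step.

On these data alone, the step rests on one pair, so it remains open whether the same exchange would give a similar step on the core of compound 1 or compound 2. Also open, as far as these compounds go, is how this position would respond to an unsubstituted phenyl, to a phenyl carrying a single chlorine, or to a phenyl carrying an amine or a carboxylic acid.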